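This account rests on a few compounds, and the source may have more. Where it says the series, first, only, none or still open, it means among the compounds named here.

The two measured compounds share a core bearing a thiocarbonyl joined to a cyclic amine. Compound 1 `N/C(=N\NC(=S)N1CCOCC1)c1ccccn1` carries morpholin-4-yl on that thiocarbonyl carbon, and in a functional assay on HeLa cells (Homo sapiens) for cytotoxicity, read by MTT assay, with a stated time of 72 h (a lower number here means a stronger inhibitor, a higher number a weaker inhibitor), compound 1 gives 7300 nM. Compound 2 `Cc1cccc(/C(N)=N/NC(=S)N2CCSCC2)n1` carries thiomorpholin-4-yl in the same place and also differs from compound 1 elsewhere on the core; in this assay compound 2 gives 1800 nM. Of the two numbers in hand, compound 2 holds the lower one, and its gap to compound 1 lies beyond the usual scatter. Since compound 1 and compound 2 differ in two places at once, their two values cannot show which change carries that gap.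

Compound 3 `Cc1cccc(/C(N)=N/NC(=S)N2CCOCC2)n1` has not yet been measured in this assay. It differs from compound 2 in one place only: morpholin-4-yl in place of thiomorpholin-4-yl on a thiocarbonyl carbon. This exchange takes compound 3 one step toward compound 1 while keeping the rest of compound 2 intact. Going by the values given here, no measured pair shows this single change by itself, so the expectation must lean on the two values of compound 1 and compound 2. Because compound 1, which bears morpholin-4-yl, gives 7300 nM, a moderate step toward a higher number is expected, estimated as a 2.1-fold higher number from compound 2 to compound 3 (0.32 log units; beyond the scatter). Compound 3 is accordingly expected to give about 3800 nM, most likely within 1500 nM to 10000 nM.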

Compound 3, half-maximal inhibitory concentration: 2200 nM
Compound 3: middle estimate off by 1.7-fold (0.24 log units), on the high side, and the stated range covers the measured number.
By their numbers in this assay, from the lowest: compounds 2 and 3 (each within the scatter of the next); then compound 1.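

In this assay, the exchange on the thiocarbonyl carbon can now be read by itself: with morpholin-4-yl in place of thiomorpholin-4-yl and the rest of the structure unchanged, there is a 1.2-fold higher number from compound 2 to compound 3 (0.09 log units; within the scatter), so this pair shows no separable difference between the two rings at this position. The gap seen earlier can now be followed to the other change, methyl in place of hydrogen on an aromatic carbon, which with morpholin-4-yl held fixed gives a 3.3-fold lower number from compound 1 to compound 3 (0.52 log units; beyond the scatter), a modest step but the only one of the two that exceeds the scatter. Nothing available bears on what lies behind either result.

The methyl step is shown here only with morpholin-4-yl on the thiocarbonyl carbon, so whether it holds with thiomorpholin-4-yl remains open. Also open, going by these compounds, is how this assay would respond to an ethyl or methoxy group in place of that methyl, or to piperidin-1-yl or piperazin-1-yl on the thiocarbonyl carbon.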